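Removing a tert-butyl group from a carbamate ester

This account rests on a few compounds, and the source may have more. Where it says the series, first, only, none or still open, it means among the compounds named here.

Compound 1 `Cc1cn(C2CC(N=[N+]=[N-])C(COC(=O)NCCCC(=O)OC(C)(C)C)O2)c(=O)[nH]c1=O`: > 50000 nM (a limit)
Compound 2 `Cc1cn(C2CC(N=[N+]=[N-])C(COC(=O)OCCCCCCO)O2)c(=O)[nH]c1=O`: > 50000 nM (a limit)

Within the data shown here, both compounds have so far been tested in a functional assay on MT4 cells (Homo sapiens) for cytotoxicity; a lower number here means that less compound is tolerated, a higher number that more compound is tolerated. In this assay compound 1 gives > 50000 nM, which is a limit and not a number. Compound 2 gives > 50000 nM, which is also a limit. Among the measured compounds shown here, compound 1 therefore has no exact position on the scale, and the only comparison available is the limit of > 50000 nM in this assay, at which 2 of the 2 values shown sit.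

The next compound to be measured is compound 3 `Cc1cn(C2CC(N=[N+]=[N-])C(COC(=O)NCCCC(=O)O)O2)c(=O)[nH]c1=O`. It differs from compound 1 by hydrogen in place of tert-butyl on an oxygen next to a carbonyl group. In words, hydrogen stands in place of tert-butyl on an oxygen next to a carbonyl group, so that tert-butoxycarbonyl becomes carboxy, while the rest of the structure stays the same.

For the measured compounds named here, no measured pair shows the size of such a change. With compound 1 at > 50000 nM, a limit, no change beyond the usual scatter is expected in either direction. The estimated step is a number no higher from compound 1 to compound 3 (the limit leaves the size open), and another limit is the likeliest report. For compound 3 the expected value is 50000 nM, with an estimated range of 25000 nM to 100000 nM.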

Compound 3, half-maximal cytotoxic concentration: > 50000 nM
Compound 3: no number, only a limit; the forecaster's own chance of this, stated with the estimate: 85%; the middle value sits exactly at the limit.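

In this assay compound 3 gives > 50000 nM, which is a limit and not a number. Among these compounds, no step from compound 1 or compound 2 to compound 3 can be read, and the three compounds share one limit: the limit of > 50000 nM in this assay, at which 3 of the 3 values shown sit. The compounds shown leave open at what concentration any of them becomes cytotoxic, and whether hydrogen in place of tert-butyl changes that concentration.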